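Sulfonyl aryl variation and metabotropic glutamate receptor 5 binding

The source may report more compounds than this note shows. Statements on the series, on what has been measured and on what is new or still open speak of the compounds shown alone.

Compound 1 `Cc1ccc(S(=O)(=O)c2cnc3ccc(F)cc3c2N2CCC(C)CC2)cc1`: 91%
Compound 2 `CC1CCN(c2c(S(=O)(=O)c3cccc(F)c3)cnc3ccc(F)cc23)CC1`: 76%
Compound 3 `CC1CCN(c2c(S(=O)(=O)c3ccc(F)c(Cl)c3)cnc3ccc(F)cc23)CC1`: 95%

All three compounds share a core and differ only in the aryl group on the sulfonyl sulfur. In an assay on isolated protein for displacement of a labelled ligand from metabotropic glutamate receptor 5 (Homo sapiens), with a stated time of 60 min, tested at 1 uM (a higher number here means more inhibition at the concentration tested (going by the name of the read-out), a lower number less inhibition), compound 3 gives 95%, the highest of the three numbers, though its gap to compound 1 lies within the scatter, so the two cannot be ordered; only compound 2 sits clearly apart, with a number 19 percentage points higher from compound 2 to compound 3 (beyond the scatter) and a number 15 percentage points lower from compound 1 to compound 2 (beyond the scatter), while a number 4 percentage points higher from compound 1 to compound 3 (within the scatter) is within the scatter.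

Compound 4 `CC1CCN(c2c(S(=O)(=O)c3ccc(C#N)cc3)cnc3ccc(F)cc23)CC1` has not yet been measured. It carries 4-cyanophenyl in place of 3-chloro-4-fluorophenyl on a sulfonyl sulfur. Among the compounds with values here, no measured step swaps a ring for a 4-cyanophenyl, so the only guidance is that aryl changes here have moved the read-out by modest amounts at most, and two of three arylsulfonyl variants sit near the top of the range. The step is therefore expected to be small and, if anything, downward: a number 10 percentage points lower from compound 3 to compound 4 (within the scatter). For compound 4 in this assay a value of about 85% is estimated, with a range of 65% to 96%.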

Compound 4, a percentage reported as inhibition, at one concentration (the size of the read-out at that concentration, not a potency): 75%
For compound 4 the middle estimate is 10 percentage points above the measured one, within the range that was stated.
By their numbers in this assay, from the lowest: compounds 4 and 2 (each within the scatter of the next); then compounds 1 and 3 (each within the scatter of the next).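

In this assay the 4-cyanophenyl group on the sulfonyl sulfur gives a clear fall from both upper compounds, with a number 20 percentage points lower from compound 3 to compound 4 (beyond the scatter) and a number 16 percentage points lower from compound 1 to compound 4 (beyond the scatter) beyond the scatter. It lands level with the 3-fluorophenyl ring, with a number 1 percentage points lower from compound 2 to compound 4 (within the scatter), so the read-out at this position now separates into an upper and a lower pair. The step from compound 1 is the plainest reading, as cyano in place of methyl on an aromatic carbon is enough on its own to move the number beyond the scatter, but nothing measured here explains these differences.

The compounds shown leave open whether an aryl ring is needed on the sulfonyl sulfur at all, and how a methoxy group or an amine would read in place of the cyano. Going by these compounds, with compound 1 at 91% and compound 3 at 95% at a single concentration, how those two compare in potency also remains open.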